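Swapping the Sulfonyl Aryl Group: From Dimethoxy to Nitro

The source may report more compounds than this note shows. Statements on the series, on what has been measured and on what is new or still open speak of the compounds shown alone.

Measured so far:
compound 1 `CN(c1ccc2[nH]c(-c3n[nH]c4ccccc34)cc2n1)S(=O)(=O)c1ccc(Cl)cc1` — 8350 nM
compound 2 `COc1ccc(S(=O)(=O)N(C)c2ccc3[nH]c(-c4n[nH]c5ccccc45)cc3n2)cc1OC` — 10100 nM

In a functional assay on KB cells (Homo sapiens) for antiproliferative activity, read by MTT assay, with a stated time of 72 h (a higher number here means a weaker inhibitor, a lower number a stronger inhibitor), compound 2 gives 10100 nM, the highest of the two numbers shown. Its nearest neighbour is compound 1, and a 1.2-fold higher number from compound 1 to compound 2 (0.08 log units; within the scatter). Compound 3 `CN(c1ccc2[nH]c(-c3n[nH]c4ccccc34)cc2n1)S(=O)(=O)c1cccc([N+](=O)[O-])c1` differs from compound 2 in one place: 3-nitrophenyl in place of 3,4-dimethoxyphenyl on a sulfonyl sulfur. Within the data shown here, the only measured step, a 1.2-fold higher number from compound 1 to compound 2 (0.08 log units; within the scatter), also exchanged the aryl group on the sulfonyl sulfur and stayed within the scatter, so no step beyond the scatter is expected here either. Compound 3 is therefore estimated at 9000 nM, with a range from 4500 nM to 18000 nM. That estimate implies an expected 1.1-fold lower number from compound 2 to compound 3 (0.05 log units; within the scatter).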

Compound 3, half-maximal inhibitory concentration: 5870 nM
Compound 3: middle estimate off by 1.5-fold (0.19 log units), on the high side; the range from low to high includes it.
By their numbers in this assay, from the lowest: compounds 3, 1 and 2 (each within the scatter of the next).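

In this assay, the aryl group on the sulfonyl sulfur now comes in three forms, and the new steps, a 1.7-fold lower number from compound 2 to compound 3 (0.24 log units; within the scatter) and a 1.4-fold lower number from compound 1 to compound 3 (0.15 log units; within the scatter), both lie within the scatter. Adding 3-nitrophenyl therefore still gives no measurable separation at this position: 4-chlorophenyl, 3,4-dimethoxyphenyl and 3-nitrophenyl cannot be told apart here. No accompanying measurement bears on why this is so. Going by these compounds, all three compounds carry an aryl group at this position, so it remains open whether an amine, a carboxylic acid or a longer alkyl chain on the sulfonyl sulfur would give a step beyond the scatter.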